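Spiro oxindole series: carrageenan paw edema inhibition

A few compounds are considered here, and "the series" means these few. Any claim that something is new, unique, unknown or untested is made for them only; others in the source may bear on it.

Compound 1 `Cc1ccc([C@@H]2CN(C)[C@]3(C(=O)Nc4ccccc43)[C@]23Cc2ccccc2C3=O)cc1` was tested in a functional assay on the whole organism (strain Wister albino) for inhibition, with Rattus norvegicus as the target, read by paw edema, with stated times of 1 h and 3 h, at a dose of 50 mg/kg by the intraperitoneal route (a lower number here means less inhibition, a higher number more inhibition at the dose given (going by the name of the read-out)), where compound 1 gives 27.4%. Compound 2 `CN1C[C@@H](c2cccs2)[C@@]2(Cc3ccccc3C2=O)[C@@]12C(=O)Nc1ccccc12` differs from it by thiophen-2-yl in place of 4-methylphenyl on a saturated ring carbon, and compound 2 gives 32.6%, a step of a number 5.2 percentage points higher from compound 1 to compound 2 (within the scatter). Compound 3 `Cc1ccc([C@@H]2CN(C)[C@]3(C(=O)N(C)c4ccccc43)[C@]23Cc2ccccc2C3=O)cc1` differs from compound 1 by methyl in place of hydrogen on an amide-type nitrogen in a ring, and compound 3 gives 6.4%, a step of a number 21 percentage points lower from compound 1 to compound 3 (beyond the scatter). Compound 4 `CN1C(=O)[C@@]2(c3ccccc31)N(C)C[C@@H](c1cccs1)[C@@]21Cc2ccccc2C1=O` has not yet been measured; it differs from compound 3 by thiophen-2-yl in place of 4-methylphenyl on a saturated ring carbon, the same change as from compound 1 to compound 2. Since that earlier change gave a step of a number 5.2 percentage points higher from compound 1 to compound 2 (within the scatter), a step of similar size, a number 4.6 percentage points higher from compound 3 to compound 4 (within the scatter), is expected from compound 3 to compound 4. Compound 4 is therefore estimated at 11%, within a range from 0% to 26%.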

Compound 4, a percentage reported as inhibition, in the whole organism at one dose (the size of the read-out at that dose, not a potency): 9.1%
Estimate against measurement, compound 4: 1.9 percentage points above; the measured number falls inside the stated range.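

In this assay, thiophen-2-yl in place of 4-methylphenyl behaved on the N-methylated core as it did on the other, a number 2.7 percentage points higher from compound 3 to compound 4 (within the scatter), and the two steps agree: the same change on two cores in this assay, a number 5.2 percentage points higher (within the scatter) from compound 1 to compound 2 and a number 2.7 percentage points higher (within the scatter) from compound 3 to compound 4, 2.5 percentage points apart, within the scatter of two such steps. Methyl in place of hydrogen on the amide-type nitrogen also carried across, a number 23.5 percentage points lower from compound 2 to compound 4 (beyond the scatter), matching its earlier step: the same change on two cores in this assay, a number 21 percentage points lower (beyond the scatter) from compound 1 to compound 3 and a number 23.5 percentage points lower (beyond the scatter) from compound 2 to compound 4, 2.5 percentage points apart, within the scatter of two such steps. This shows that both changes transfer between these two cores, but the thiophen-2-yl steps lie within the scatter, so they show no readable effect of that change on either core, and two cores cannot establish a general rule for the series.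

The compounds shown leave open whether a pyridyl ring or a 4-chlorophenyl on that saturated ring carbon would fit the same picture. They also leave open whether an ethyl or benzyl group on the amide-type nitrogen would lower the number as methyl does.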